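Moving the methyl around the phenyl ring of compound 2

A few compounds are considered here, and "the series" means these few. Any claim that something is new, unique, unknown or untested is made for them only; others in the source may bear on it.

Compound 1, with the structure `Cc1ccc(/C=C2\CN(CC(=O)O)c3c(C)cccc3C2=O)cc1`, and compound 2, with the structure `Cc1ccc(/C=C2\CN(CC(=O)O)c3c(Cl)cccc3C2=O)cc1`, share one core and differ at a single aromatic carbon. In an assay on HL-60 cells for inhibition of glutathione S-transferase P (Homo sapiens), read by spectrophotometry, tested at 20 uM (on this read-out higher numbers stand for more inhibition at the one concentration tested (going by the name of the read-out) and lower numbers for less inhibition), compound 1 gives 46.8%, while compound 2 gives 67.6%. Within the data shown here, the one measured step, chloro in place of methyl on an aromatic carbon, gives a number 20.8 percentage points higher from compound 1 to compound 2 (beyond the scatter). Among the measured compounds shown here, on these two numbers compound 2 stands highest, with compound 1 the only neighbour and lying beyond the scatter below it.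

Compound 3, with the structure `Cc1cccc(/C=C2\CN(CC(=O)O)c3c(Cl)cccc3C2=O)c1`, keeps the chloro of compound 2 and changes only the pendant ring: 3-methylphenyl in place of 4-methylphenyl on a double-bonded chain carbon bound to a double-bonded ring carbon. For the measured compounds named here, no measured step touches this part of the molecule, so the chloro-for-methyl step from compound 1 to compound 2 offers no direct guide. With nothing shown to pull the number either way, the estimated step in this assay is expected to be a number 3.6 percentage points lower from compound 2 to compound 3 (within the scatter), that is, none beyond the scatter. Compound 3 is therefore estimated at 64%, with a range from 44% to 80%.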

Compound 3, a percentage reported as inhibition, at one concentration (the size of the read-out at that concentration, not a potency): 45.6%
Compound 3: the middle estimate sits 18.4 percentage points above what was measured; measured number inside the range.
By their numbers in this assay, from the lowest: compounds 3 and 1 (each within the scatter of the next); then compound 2.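

In this assay, the 3-methylphenyl in place of 4-methylphenyl gives a number 22 percentage points lower from compound 2 to compound 3 (beyond the scatter), so the same atoms, joined differently, are enough to change the reading. Among these compounds, until now, the only measured change was on the aromatic carbon of the shared core; this step shows that the read-out also responds to the pendant ring, on a double-bonded chain carbon bound to a double-bonded ring carbon, even though the two groups match in heavy atoms, hydrogen-bond donors and acceptors, and net charge. Nothing available here accounts for the size of this step.

As far as these compounds go, it remains open what a plain phenyl, a 4-methoxyphenyl or a 4-aminophenyl group would give at this place, and so whether the number of compound 2 depends on the methyl itself or only on where it sits. From the compounds shown here alone, it also remains open whether the same shift of the methyl would have a similar effect on the core of compound 1, which carries a methyl where compound 2 carries its chloro.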